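The source may hold more compounds than are shown below. What is called first, only, known or untested is meant among the compounds shown, and "the series" means these compounds.

Values so far in a physicochemical assay for solubility, read by nephelometry, in phosphate buffer, at pH 7.4; on this read-out lower numbers stand for lower solubility and higher numbers for higher solubility
- compound 1 `Cc1sc(-c2ccccc2C(=O)NCCO)cc1C(=O)Nc1nc2c(s1)CCC2` gives 980 nM
- compound 2 `Cc1sc(-c2ccccc2C(=O)NCCC(N)=O)cc1C(=O)Nc1nc2c(s1)CCC2` gives 3910 nM
- compound 3 `CC(=O)N1CCCC1c1cc(C(=O)Nc2nc3c(s2)CCC3)c(C)s1` gives 7810 nM

Compound 3 (7810 nM) lies within the scatter of compound 2 and well apart from compound 1, so these two share the upper end of the three numbers.

Compound 4 `Cc1sc(N2CCCCC2=O)cc1C(=O)Nc1nc2c(s1)CCC2` keeps the shared core of compound 3 and carries 2-oxopiperidin-1-yl in place of 1-acetylpyrrolidin-2-yl on an aromatic carbon.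

Among the compounds with values here, no measured step covers this exchange. The only one, a 4.0-fold higher number from compound 1 to compound 2 (0.60 log units; beyond the scatter), is a different change, carbamoyl in place of hydroxy on a saturated chain carbon, and it offers no more than a rough idea of how far one change can move this assay in this set. The estimated step is a 1.7-fold lower number from compound 3 to compound 4 (0.24 log units; within the scatter), so nothing beyond the scatter is expected, with only a slight lean towards a lower number. For compound 4 the estimate is 4500 nM, with an expected range from 1500 nM to 12000 nM.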

Compound 4, solubility: 980 nM
Estimate against measurement, compound 4: 4.6-fold (0.66 log units) above; the measured number lies below the stated range.
By their numbers in this assay, from the lowest: compounds 1 and 4 (each within the scatter of the next); then compounds 2 and 3 (each within the scatter of the next).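

In this assay, placing 2-oxopiperidin-1-yl instead of 1-acetylpyrrolidin-2-yl on the aromatic carbon next to the ring sulfur gives an 8.0-fold lower number from compound 3 to compound 4 (0.90 log units; beyond the scatter), the first sign that this position can move the read-out beyond the scatter. The two groups have the same hydrogen-bond donor and acceptor counts and no net charge, so a step of this size occurs here without any change in those counts. No measured evidence bears on what lies behind the step.

This single pair does not separate the change in ring size from the change in how the ring and its carbonyl are arranged. As far as these compounds go, the response of this assay to an amine or a carboxylic acid at this position, or to 2-oxopyrrolidin-1-yl as a closer match to either group, remains open.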